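Shifting a Single Fluorine on the Shared Core

The compounds below may be only part of what the source reports. "The series", "measured", "known", "first", "only" and "open" are said of these compounds alone.

Compound 1 `CC(=NNC(=S)Nc1ccccc1)c1ccccn1` is the reference point here. In a functional assay on MCF7 cells (Homo sapiens) for cytotoxicity, read by MTT assay, with a stated time of 48 h (on this read-out higher numbers stand for weaker inhibition and lower numbers for stronger inhibition), compound 1 gives 0.18 nM, the lowest of the three numbers measured. Compound 2 `CC(=NNC(=S)Nc1ccc(F)cc1)c1ccccn1` gives 1.2 nM and compound 3 `CC(=NNC(=S)Nc1ccc([N+](=O)[O-])cc1)c1ccccn1` gives 52 nM, so the step of a 6.7-fold higher number from compound 1 to compound 2 (0.82 log units; beyond the scatter) is modest while a 290-fold higher number from compound 1 to compound 3 (2.46 log units; beyond the scatter) is large.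

Compound 4 `CC(=NNC(=S)Nc1cccc(F)c1)c1ccccn1` differs from compound 1 only by fluoro in place of hydrogen on an aromatic carbon, the fluoro now standing meta to a large group. Within the data shown here, the step of a 6.7-fold higher number from compound 1 to compound 2 (0.82 log units; beyond the scatter) is the only measured change that bears on this, since it also places a single fluoro on the same core, and it weakened inhibition modestly. A similar modest weakening is therefore expected for the meta position, with room for a smaller effect.

The expected step is a 4.4-fold higher number from compound 1 to compound 4 (0.65 log units; beyond the scatter), and compound 4 is estimated at 0.8 nM, within 0.25 nM to 3 nM.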

Compound 4, half-maximal inhibitory concentration: 9 nM
Beside the measured number, compound 4's estimate is 11-fold (1.05 log units) below it, and the stated range ends below it.
By their numbers in this assay, from the lowest: compound 1; then compound 2; then compound 4; then compound 3.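

Placed meta to a large group, fluoro in place of hydrogen gives a large step, a 50-fold higher number from compound 1 to compound 4 (1.70 log units; beyond the scatter), and compound 4 at 9 nM stands above compound 2 at 1.2 nM in this assay. The earlier compounds shown here showed only that adding a fluoro costs something; these values show that where the single fluoro stands on the ring also matters. Nothing available explains the gap between the two fluoro positions.

On these data alone, whether an amine or a methoxy group in this same place would also raise the number remains open.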